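This account rests on a few compounds, and the source may have more. Where it says the series, first, only, none or still open, it means among the compounds named here.

In a functional assay on Ehrlich cells (Mus musculus) for antiproliferative activity, read by trypan blue exclusion, with a stated time of 2 h, tested at 100 ug/mL (a lower number here means a weaker effect, a higher number a stronger effect of the compound at the concentration tested), the three measured compounds gave these values:

Compound 1 `COc1ccc(C2C(C#N)=C(N)N(c3ccc(S(N)(=O)=O)cc3)C3=C2C(=O)CCC3)cc1`: 100%
Compound 2 `N#CC1=C(N)N(c2ccc(S(N)(=O)=O)cc2)C2=C(C(=O)CCC2)C1c1cccc([N+](=O)[O-])c1`: 71%
Compound 3 `COc1ccc(C2C(C#N)=C(N)N(c3ccc(S(N)(=O)=O)cc3)C3=C2C(=O)CCC3)c2ccccc12`: 90%

Compound 3 stands second highest of the three. Its gap to compound 1, a number 10 percentage points lower from compound 1 to compound 3 (within the scatter), lies within the scatter, whereas a number 19 percentage points higher from compound 2 to compound 3 (beyond the scatter) is a modest step beyond it. Compound 4 `Cc1ccoc1C1C(C#N)=C(N)N(c2ccc(S(N)(=O)=O)cc2)C2=C1C(=O)CCC2` differs from compound 3 as follows: 3-methylfuran-2-yl in place of 4-methoxynaphthalen-1-yl on a saturated ring carbon. For the measured compounds named here, the steps that bear on this change are the exchanges at the same saturated ring carbon, a number 29 percentage points lower from compound 1 to compound 2 (beyond the scatter) and a number 19 percentage points higher from compound 2 to compound 3 (beyond the scatter), both modest; no measured step swaps a six-membered aromatic ring for a five-membered one. Compound 4 is therefore expected to move at most modestly, with a number 10 percentage points lower from compound 3 to compound 4 (within the scatter) as the estimated step. The estimated value for compound 4 is 80%, within 60% to 100%.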

Compound 4, a percentage reported as activity, at one concentration (the size of the read-out at that concentration, not a potency): 45%
Compound 4: the middle estimate sits 35 percentage points above what was measured, and the stated range ends above it.
By their numbers in this assay, from the lowest: compound 4; then compound 2; then compounds 3 and 1 (each within the scatter of the next).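

At this saturated ring carbon in this assay, 3-methylfuran-2-yl, the only five-membered aromatic ring in the series, brings a number 45 percentage points lower from compound 3 to compound 4 (beyond the scatter) and a number 55 percentage points lower from compound 1 to compound 4 (beyond the scatter) as two large losses, along with the modest a number 26 percentage points lower from compound 2 to compound 4 (beyond the scatter) so the position tolerates less than the exchanges among the earlier groups suggested. Compound 4 now lies below all three others. No measured evidence bears on why the number falls.

The compounds shown leave open whether the loss follows the furan ring or its methyl group. An unsubstituted furan-2-yl or a thiophen-2-yl at this carbon would bear on that.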